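This account rests on a few compounds, and the source may have more. Where it says the series, first, only, none or still open, it means among the compounds named here.

In an ADME assay on L6 cells (Rattus norvegicus) for cytotoxicity, read by fluorescence and resazurin assay, with a stated time of 72 h (a lower number here means that less compound is tolerated, a higher number that more compound is tolerated), compound 1 `Cc1ccc(-c2c[nH]cc2C(c2ccc(Cl)cc2Cl)n2ccnc2)cc1` gives 18400 nM and compound 2 `CC(C)c1ccc(-c2c[nH]cc2C(c2ccc(Cl)cc2Cl)n2ccnc2)cc1` gives 12700 nM so the two stand level within the scatter. Compound 3 `COc1ccc(-c2c[nH]cc2C(c2ccc(Cl)cc2Cl)n2ccnc2)cc1` differs from compound 2 by one group: methoxy in place of isopropyl on an aromatic carbon with methoxy in place of isopropyl on an aromatic carbon. For the measured compounds named here, the only measured step bearing on this change is a 1.4-fold lower number from compound 1 to compound 2 (0.16 log units; within the scatter) and it altered the group at that same place without moving the number beyond the scatter. No step beyond the scatter is therefore expected in this assay and the estimated step is a 1.3-fold higher number from compound 2 to compound 3 (0.10 log units; within the scatter) at most a small one. Compound 3 is estimated at 16000 nM with 8000 nM to 32000 nM as the expected range.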

Compound 3, half-maximal cytotoxic concentration: 14800 nM
The estimate for compound 3 lay 1.1-fold (0.03 log units) above the measured number; the measured number falls inside the stated range.
By their numbers in this assay, from the lowest: compounds 2, 3 and 1 (each within the scatter of the next).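

In this assay, methoxy brings in a hydrogen-bond acceptor where isopropyl and methyl have none, yet this change gives a 1.2-fold higher number from compound 2 to compound 3 (0.07 log units; within the scatter), and methoxy in place of methyl gives a 1.2-fold lower number from compound 1 to compound 3 (0.09 log units; within the scatter). At this place, para to a large group, all three groups therefore stand level, so adding an oxygen has no readable effect here. Nothing measured here explains why the number holds steady. On these data alone, whether an amine or a carboxylic acid at this place would move the number beyond the scatter remains open.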